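The source may report more compounds than this note shows. Statements on the series, on what has been measured and on what is new or still open speak of the compounds shown alone.

Compound 1 `CCCCCCCCCCn1cc(-c2nc3ccccc3cc2CC)nn1` and compound 2 `CCCCCCCCCCn1cc(-c2nc3ccccc3cc2CCC)nn1` carry a long unbranched chain without fluorine, while compound 3 `CCc1cc2ccccc2nc1-c1cn(CCC(F)(F)C(F)(F)C(F)(F)C(F)(F)C(F)(F)C(F)(F)C(F)(F)C(F)(F)F)nn1` and the not yet measured compound 4 `CCCc1cc2ccccc2nc1-c1cn(CCC(F)(F)C(F)(F)C(F)(F)C(F)(F)C(F)(F)C(F)(F)C(F)(F)C(F)(F)F)nn1` carry a long fluorinated chain instead. The difference between the two cores is not broken down here. Within each pair the change is the same: from compound 1 to compound 2 it is methyl in place of hydrogen on a saturated chain carbon, two bonds along the chain from an aromatic carbon, and from compound 3 to compound 4 it is methyl in place of hydrogen on a saturated chain carbon, two bonds along the chain from an aromatic carbon. In a functional assay on U-937 cells (Homo sapiens) for cytotoxicity, read by MTT assay, with a stated time of 24 h (on this read-out higher numbers stand for weaker inhibition and lower numbers for stronger inhibition), compound 1 gives 12.7 ug/mL, while compound 2 gives 26.6 ug/mL, so this change made a 2.1-fold higher number from compound 1 to compound 2 (0.32 log units; beyond the scatter). In this assay compound 3 gives 55.9 ug/mL, the highest number of the three. The same kind of step is expected here, a 2.0-fold higher number from compound 3 to compound 4 (0.29 log units; within the scatter), because the identical change gave a 2.1-fold higher number from compound 1 to compound 2 (0.32 log units; beyond the scatter). That expectation rests on a single measured example only. Compound 4 is therefore estimated at 110 ug/mL, with a likely range from 55 ug/mL to 220 ug/mL.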

Compound 4, half-maximal inhibitory concentration: > 100 ug/mL
Compound 4 was reported as a limit (the forecaster's own chance of this, stated with the estimate: 20%); the middle value is on the limit's open side.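

In this assay compound 4 gives > 100 ug/mL, which is a limit of the assay and not a number. Going from ethyl to propyl on the core with the fluorinated chain gives an at least 1.7-fold higher number from compound 3 to compound 4 (0.25 log units; that floor lies within the scatter), so the direction seen on the other core is not contradicted, but the true size of this step stays unknown. The two cores therefore cannot be said to respond either alike or differently: the same change on two cores in this assay, a 2.1-fold higher number (0.32 log units; beyond the scatter) from compound 1 to compound 2 and an at least 1.7-fold higher number (0.25 log units; that floor lies within the scatter) from compound 3 to compound 4; the limit leaves it open whether they differ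

The compounds shown carry only ethyl and propyl at this place, so a longer chain such as butyl, or an amine, remains open. From the compounds shown here alone, how the same change behaves with a shorter fluorinated chain also remains open.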